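The compounds below may be only part of what the source reports. "The series", "measured", "known", "first", "only" and "open" are said of these compounds alone.

Measured compounds:
- compound 1, `Cc1cc(F)c(CNc2ncc(-c3cccnc3C)c3nncn23)c2c1OCC2`: "not determined" (no result reported)
- compound 2, `Cc1ncccc1-c1cnc(NCc2c(F)cc(C3CC3)c3c2CCO3)n2cnnc12`: "not determined" (no result reported)
- compound 3, `Cc1ncccc1-c1cnc(NCc2c(F)cc(C#N)c3c2CCO3)n2cnnc12`: 10 uL/min

In an ADME assay on cells (Hepatocyte, Rattus norvegicus) for metabolic stability (a lower number here means slower removal, a higher number faster removal of the compound), compound 1 has no number; its entry reads "not determined" (no result reported). The same holds for compound 2, which in this assay gives "not determined" (no result reported). Within the data shown here, compound 3 is the only compound of the series with a result: in this assay compound 3 gives 10 uL/min. Since compound 1 carries no number, its standing relative to compound 3 cannot be told.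

Compound 4, `COc1cc(F)c(CNc2ncc(-c3cccnc3C)c3nncn23)c2c1OCC2`, is not yet measured. It differs from compound 1 in one place: methoxy in place of methyl on an aromatic carbon. Among the measured compounds shown here, no step between two measured compounds bears on this change, so the direction cannot be read from the series. For the measured compounds named here, nothing here argues for a step beyond the scatter in this assay in either direction, and the one number available, that of compound 3, gives the only anchor for the scale of the series.

Compound 4 is therefore expected to give about 15 uL/min in this assay, estimated to lie between 5 uL/min and 45 uL/min.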

Compound 4, intrinsic clearance in a liver preparation (reported as CLH), per the amount of preparation that the assay uses: 4 uL/min
Compound 4: middle estimate off by 3.8-fold (0.57 log units), on the high side, outside the stated range (below it).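

In this assay, the substituted aromatic carbon now has its first readable step: methoxy in place of cyano gives a 2.5-fold lower number from compound 3 to compound 4 (0.40 log units; beyond the scatter), which shows that the read-out responds to the group at this position while the rest of the structure stays the same. Among these compounds, the steps involving the methyl of compound 1 and the cyclopropyl of compound 2 cannot be read, so this single pair is the only comparison at this carbon. No measurement shown accounts for the difference between methoxy and cyano.

Open, going by these compounds, is whether the lower number holds for other oxygen-linked groups at this carbon, such as ethoxy or a longer alkoxy chain. Also open, on these data alone, is how an amine or a carboxylic acid at the same carbon would read in this assay.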